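A few compounds are considered here, and "the series" means these few. Any claim that something is new, unique, unknown or untested is made for them only; others in the source may bear on it.

Compound 1 `CCCOc1cccnc1Nc1cccc(C)n1` gives 1600 nM.
Compound 2 `Cc1cccc(Nc2ncccc2OCc2ccccc2)n1` gives 870 nM.
Compound 3 `CCOc1cc(-c2cccc(F)c2)cnc1Nc1cccc(C)n1` gives 126 nM.

In an assay on Ltk cells with metabotropic glutamate receptor 5 (Homo sapiens) as the target, read by fluorescence and calcium flux (a higher number here means a weaker inhibitor, a lower number a stronger inhibitor), compound 3 stands lowest of the three numbers, and the gaps to compound 2 and to compound 1 both lie beyond the scatter. Compound 4 `CCOc1cc(Oc2cccnc2)cnc1Nc1cccc(C)n1` differs from compound 3 by (pyridin-3-yl)oxy in place of 3-fluorophenyl on an aromatic carbon. Within the data shown here, no measured step touches this site: the only step recorded, a 1.8-fold lower number from compound 1 to compound 2 (0.26 log units; within the scatter), concerns the alkoxy chain and stayed within the scatter. Compound 3 therefore serves as the anchor, and compound 4 is expected to move by a 2.0-fold higher number from compound 3 to compound 4 (0.30 log units; within the scatter) in this assay, with a wide range around it. Compound 4 is estimated at 250 nM, between 80 nM and 800 nM.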

Compound 4, half-maximal inhibitory concentration: 18 nM
Compound 4: the middle estimate sits 14-fold (1.14 log units) above what was measured; measured number below the stated range.
By their numbers in this assay, from the lowest: compound 4; then compound 3; then compounds 2 and 1 (each within the scatter of the next).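

At the carbon para to the (6-methylpyridin-2-yl)amino group, (pyridin-3-yl)oxy in place of 3-fluorophenyl gives a 7.0-fold lower number from compound 3 to compound 4 (0.85 log units; beyond the scatter) in this assay, so this position answers to the group it carries, a step beyond the scatter where the alkoxy step was not. The two groups have the same heavy-atom count, but the entering one carries 2 hydrogen-bond acceptors and the leaving one 0. Nothing available explains the difference.

This single step does not separate the oxygen link from the ring nitrogen. As far as these compounds go, how phenoxy, pyridin-3-yl or an amine would read at this carbon remains open.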